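One Stereocentre Turned on a Cytotoxicity-Silent Compound

The source may hold more compounds than are shown below. What is called first, only, known or untested is meant among the compounds shown, and "the series" means these compounds.

Compound 1 `Cc1cn(C2COCO2)c(=O)[nH]c1=O` and compound 2 `O=c1ccn([C@@H]2CO[C@@H](CO)O2)c(=O)[nH]1` were both tested in a functional assay on cells (Homo sapiens) for cytotoxicity; on this read-out lower numbers stand for stronger inhibition and higher numbers for weaker inhibition. For compound 2 the result is only a limit of the assay, > 100000 nM. For compound 1 the result is likewise a limit, > 100000 nM. Both values sit at the limit of > 100000 nM in this assay, at which 2 of the 2 values shown sit. Compound 3 `O=c1ccn([C@H]2CO[C@@H](CO)O2)c(=O)[nH]1` is yet to be measured; it differs from compound 2 only in configuration: the two compounds have the same atoms and bonds and differ only in configuration as drawn: 1 of 2 stereo elements differ; a stereocentre at a saturated ring carbon is drawn S in compound 2 and R in compound 3. For the measured compounds named here, no measured pair shows what such a change does in this assay, so no step beyond the scatter is expected in either direction. Compound 3 is expected to give 100000 nM, ranging from 30000 nM to 300000 nM, a step of a number no higher from compound 2 to compound 3 (the limit leaves the size open).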

Compound 3, half-maximal inhibitory concentration: > 100000 nM
Compound 3: no number, only a limit; the forecaster's own chance of this, stated with the estimate: 85%; the middle value lies on the limit itself.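

Compound 3 gives only a limit of the assay, > 100000 nM. No step can be read between compound 2 and compound 3. The compounds shown leave open whether this change of configuration alters cytotoxicity in this assay at all.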